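A Side-Chain Exchange on Compound 2, Weighed Before Measurement

This account rests on a few compounds, and the source may have more. Where it says the series, first, only, none or still open, it means among the compounds named here.

Of the compounds shown here, three have so far been tested in a functional assay on the whole organism (Tail, strain ICR) with Mus musculus as the target, in the tail flick test, with a stated time of 150 min, at a dose of 25 umol/kg by the oral route; on this read-out lower numbers stand for a weaker effect and higher numbers for a stronger effect at the one dose given. Compound 1 `O=C(O)[C@@H]1CCCN1C(=O)CN(c1nc(Cl)nc2[nH]cnc12)C1CC1` gives 7.29%. Compound 2 `CSCC[C@H](NC(=O)CN(c1ncnc2c1ncn2C1CCCCO1)C1CC1)C(=O)OCc1ccccc1` gives 17.5% in this assay, and compound 3 `CC(C)[C@H](NC(=O)CN(c1nc(Cl)nc2[nH]cnc12)C1CC1)C(=O)OCc1ccccc1` gives 17.9%; the numbers for compounds 2 and 3 lie within the scatter of each other, whereas compound 2 stands beyond the scatter above compound 1. Compound 4 `O=C(CN(c1ncnc2c1ncn2C1CCCCO1)C1CC1)N[C@@H](CC(=O)OCc1ccccc1)C(=O)OCc1ccccc1` has not yet been measured. It differs from compound 2 in one place: benzyloxycarbonyl in place of (methylsulfanyl)methyl on a saturated chain carbon, two bonds along the chain from an amide-type nitrogen and a carbonyl carbon. Among the measured compounds shown here, no pair of measured compounds shares a single change, so this exchange has no measured precedent here. In this assay the expected step is small, a number 2.5 percentage points lower from compound 2 to compound 4 (within the scatter), within the usual scatter. Compound 4 is therefore estimated at 15%, with a range from 5% to 28%.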

Compound 4, a percentage reported as activity, at one dose (the size of the read-out at that dose, not a potency): 0.06%
Compound 4: the middle estimate sits 14.9 percentage points above what was measured; measured number below the stated range.
By their numbers in this assay, from the lowest: compounds 4 and 1 (each within the scatter of the next); then compounds 2 and 3 (each within the scatter of the next).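

Among the compounds shown here, at this saturated chain carbon, in this assay, benzyloxycarbonyl in place of (methylsulfanyl)methyl gives a number 17.4 percentage points lower from compound 2 to compound 4 (beyond the scatter) as the first single change with a measured step. For the compounds shown here, the position is therefore sensitive to what it carries, which the earlier compounds, differing in several places at once, could not show. Nothing measured here gives a reason for this drop.

On these data alone, this one exchange brings in the aromatic ring, the ester and the larger group together, so which of them matters stays open. As far as these compounds go, how an amine or a plain methyl would read at this carbon is also open.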